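The source may report more compounds than this note shows. Statements on the series, on what has been measured and on what is new or still open speak of the compounds shown alone.

Three compounds have been read in a functional assay (blood) for inhibition, with Homo sapiens as the target; on this read-out higher numbers stand for weaker inhibition and lower numbers for stronger inhibition:

Compound 1 `CC(C)(C)Sc1c(CC(C)(C)C(=O)O)n(Cc2ccc(Cl)cc2)c2ccc(OCc3ccc4cc(F)ccc4n3)cc12`: 880 nM
Compound 2 `CC(C)(C)Sc1c(CC(C)(C)C(=O)O)n(Cc2ccc(Cl)cc2)c2ccc(OCc3ccc4cnccc4n3)cc12`: 980 nM
Compound 3 `Cc1nc2ccc(COc3ccc4c(c3)c(SC(C)(C)C)c(CC(C)(C)C(=O)O)n4Cc3ccc(Cl)cc3)cc2s1`: > 3000 nM

Compound 3 stands at the limit of > 3000 nM in this assay, at which 1 of the 3 values shown sits. This is a limit of the assay and not a number.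

The next compound to be read, compound 4 `CC(C)(C)Sc1c(CC(C)(C)C(=O)O)n(Cc2ccc(Cl)cc2)c2ccc(OCc3ccncc3)cc12`, differs from compound 3 in one place: pyridin-4-yl in place of 2-methyl-1,3-benzothiazol-6-yl on a saturated chain carbon bound to an oxygen on an aromatic ring. It has pyridin-4-yl in place of 2-methyl-1,3-benzothiazol-6-yl on a saturated chain carbon bound to an oxygen on an aromatic ring.

Three measured steps change this same group. One, a 1.1-fold higher number from compound 1 to compound 2 (0.05 log units; within the scatter), stays within the scatter. The other two, an at least 3.4-fold higher number from compound 1 to compound 3 (0.53 log units; beyond the scatter) and an at least 3.0-fold higher number from compound 2 to compound 3 (0.48 log units; beyond the scatter), go beyond it towards weaker inhibition, and both end at the limit. They show that the group can matter in this assay, but none of them leads to pyridin-4-yl, so they bear on this change only loosely and give it no firm direction.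

No step beyond the scatter is therefore expected, and the result may again be only a limit. The expected change is an at least 1.0-fold lower number from compound 3 to compound 4 (0.02 log units; that floor lies within the scatter). For compound 4 the estimated value is 2800 nM. The expected range runs from 1000 nM to 7000 nM.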

Compound 4, half-maximal inhibitory concentration: > 3000 nM
Compound 4 gave a limit, no number (the forecaster's own chance of this, stated with the estimate: 50%); middle value at least 1.0-fold (0.02 log units) from the limit.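

In this assay, pyridin-4-yl in place of 6-fluoroquinolin-2-yl gives an at least 3.4-fold higher number from compound 1 to compound 4 (0.53 log units; beyond the scatter), and the same group in place of the group of 10 heavy atoms in compound 2 gives an at least 3.0-fold higher number from compound 2 to compound 4 (0.48 log units; beyond the scatter). A second group on the saturated chain carbon bound to an oxygen on an aromatic ring thus falls short of the values of compound 1 and compound 2, and this time the group has one six-membered aromatic ring, not two. Compound 3 and compound 4 both end at a limit and not at a number, so the step between them cannot be read, and the position now holds this limit twice: the limit of > 3000 nM in this assay, at which 2 of the 4 values shown sit.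

As far as these compounds go, how much weaker either compound lies stays open, and so does any role for the number of rings, since compound 3 has two rings like compound 1 and compound 2 yet also ends at a limit. The compounds shown also leave open how an unsubstituted quinolin-2-yl, or a pyridin-4-yl carrying an amine or a carboxylic acid, would read in this assay.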